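Benzyl-type ethers on the shared core: compound 3 to compound 4

A few compounds are considered here, and "the series" means these few. Any claim that something is new, unique, unknown or untested is made for them only; others in the source may bear on it.

Measured so far:
compound 1 `CCCOCNc1n[n+]([O-])c2cc(OC)ccc2[n+]1[O-]`: 2880 nM
compound 2 `COc1ccc2c(c1)[n+]([O-])nc(NCOCc1ccccc1)[n+]2[O-]`: 21400 nM
compound 3 `CCCCCOCNc1n[n+]([O-])c2ccccc2[n+]1[O-]`: 17000 nM

In a functional assay on SMMC-7721 cells (Homo sapiens) for cytotoxicity, read by MTT assay, with a stated time of 72 h (a higher number here means a weaker inhibitor, a lower number a stronger inhibitor), compound 3 gives the second highest of the three numbers; compound 2 lies within the scatter of it, compound 1 well below it. Compound 4 `COc1ccc(COCNc2n[n+]([O-])c3ccccc3[n+]2[O-])cc1` differs from compound 3 by 4-methoxyphenyl in place of butyl on a saturated chain carbon bound to an oxygen on a saturated carbon. For the measured compounds named here, one measured step bears on this: a 7.4-fold higher number from compound 1 to compound 2 (0.87 log units; beyond the scatter), an aryl replacing an alkyl at the same place. That step points to a higher number for compound 4, though compound 2 and compound 3 show that the cores with and without the ring substituent sit close. Compound 4 is therefore expected to show a 1.9-fold higher number from compound 3 to compound 4 (0.27 log units; within the scatter), a modest rise, estimated at 32000 nM with a range of 11000 nM to 95000 nM.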

Compound 4, half-maximal inhibitory concentration: 22000 nM
Estimate against measurement, compound 4: 1.5-fold (0.16 log units) above, and the stated range covers the measured number.
By their numbers in this assay, from the lowest: compound 1; then compounds 3, 2 and 4 (each within the scatter of the next).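

In this assay butyl to 4-methoxyphenyl at this place gives a 1.3-fold higher number from compound 3 to compound 4 (0.11 log units; within the scatter) and so, on the core of compound 3, this aromatic ring does not separate the two compounds. The aryl-for-alkyl step a 7.4-fold higher number from compound 1 to compound 2 (0.87 log units; beyond the scatter) is beyond the scatter, so such a change does not have the same size in both pairs, although their groups and cores differ. Nothing available here accounts for that contrast.

Open, on these data alone, is whether an amine or a carboxylic acid at this place would move the number beyond the scatter. Also open, as far as these compounds go, is whether the low number of compound 1 belongs to its short chain or to its core.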